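The source may report more compounds than this note shows. Statements on the series, on what has been measured and on what is new or still open speak of the compounds shown alone.

Measured in a functional assay on HL-60 cells (Homo sapiens) for activation, read by flow cytometry, with a stated time of 4 days; a higher number here means that more compound is needed for the effect, a lower number that less compound is needed:
compound 1 `COc1ccc(-n2cnc3cnc(-c4ccc(F)cc4C)cc32)cc1OC` gives 15 nM
compound 2 `COc1ccc(-n2cnc3cnc(-c4cc(F)ccc4OC)cc32)cc1OC` gives 1300 nM
compound 3 `COc1ccc(-n2cnc3cnc(-c4ccc(F)cc4C)cc32)cc1` gives 6 nM

Compound 3 stands at the lowest number of the three: the step of a 2.5-fold lower number from compound 1 to compound 3 (0.40 log units; beyond the scatter) is beyond the scatter, and compound 2, at 1300 nM, lies far above it. Compound 4 `Cc1ccc(-n2cnc3cnc(-c4ccc(F)cc4C)cc32)cc1` differs from compound 3 in a single place: methyl in place of methoxy on an aromatic carbon.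

Among the measured compounds shown here, only one measured step touches this ring. The step of a 2.5-fold lower number from compound 1 to compound 3 (0.40 log units; beyond the scatter) shows that taking the methoxy away altogether, leaving hydrogen, gave a modest drop in the number. The other step, an 87-fold higher number from compound 1 to compound 2 (1.94 log units; beyond the scatter), concerns the other aromatic ring and does not bear on this change. For the measured compounds named here, no measured pair swaps methoxy for methyl, so the direction is uncertain; with the methoxy removal giving only a modest shift, the methyl replacement is expected to give at most a small step, likely within the scatter. The estimate for compound 4 is therefore 6 nM, with a range from 2 nM to 20 nM, meaning an expected step of no change at the digits printed from compound 3 to compound 4 (within the scatter).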

Compound 4, half-maximal effective concentration: 140 nM
For compound 4 the middle estimate is 23-fold (1.37 log units) below the measured one, and the stated range ends below it.
By their numbers in this assay, from the lowest: compound 3; then compound 1; then compound 4; then compound 2.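

In this assay, among the compounds shown here, the methoxy para to a large group proves to matter far more than the earlier compounds could show, with methyl in its place giving a 23-fold higher number from compound 3 to compound 4 (1.37 log units; beyond the scatter). For the compounds shown here, the only earlier step on this ring, a 2.5-fold lower number from compound 1 to compound 3 (0.40 log units; beyond the scatter), took away the other methoxy of compound 1 and left this one in place, so it said nothing about this position. Nothing shown here explains why so small a swap gives so large a step.

The compounds shown leave open how this position would respond to hydrogen, a hydroxyl, an ethoxy group or a fluorine. They also leave open whether the same swap would give a step of similar size in compound 1, which carries a second methoxy on this ring.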